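Furan-2-yl to 4-(trifluoromethyl)phenyl on the carbonyl carbon

This account rests on a few compounds, and the source may have more. Where it says the series, first, only, none or still open, it means among the compounds named here.

The compounds share one core and differ in the group on a carbonyl carbon. In an ADME assay on cells (Hepatocyte, Mus musculus) for metabolic stability (a higher number here means that the compound lasts longer, a lower number that the compound disappears faster), compound 1 (`O=C(OC1CCC(CN2CCN(c3cc(=O)c4cc(C(F)(F)F)cc([N+](=O)[O-])c4s3)CC2)CC1)c1ccccc1`) gives 0.903 h as its half-life. Compound 2 (`O=C(OC1CCC(CN2CCN(c3cc(=O)c4cc(C(F)(F)F)cc([N+](=O)[O-])c4s3)CC2)CC1)c1ccco1`) gives < 0.075 h as a limit of the assay and not a number. Compound 2 therefore stands at the low end of the two results, with only a limit known for it.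

The change to compound 3 (`O=C(OC1CCC(CN2CCN(c3cc(=O)c4cc(C(F)(F)F)cc([N+](=O)[O-])c4s3)CC2)CC1)c1ccc(C(F)(F)F)cc1`) is 4-(trifluoromethyl)phenyl in place of furan-2-yl on a carbonyl carbon. For the measured compounds named here, the one measured step that bears on it is an at least 12-fold lower number from compound 1 to compound 2 (1.08 log units; beyond the scatter) and it is large, beyond the scatter, running opposite to the direction now considered. Like compound 1 at 0.903 h compound 3 carries a six-membered aromatic ring of carbon only on the carbonyl carbon, so a large rise is expected. Going by the values given here, no measured step covers the added trifluoromethyl group, so the range stays wide. The expected size of the change is an at least 10-fold higher number from compound 2 to compound 3 (1.02 log units; beyond the scatter) in this assay as an estimated increase. For compound 3 the estimate is 0.8 h with an expected range from 0.25 h to 2.5 h as its half-life.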

Compound 3, half-life: 0.278 h
Compound 3: middle estimate off by 2.9-fold (0.46 log units), on the high side; low and high end bracket the measured number.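

On the carbonyl carbon, a six-membered aromatic ring of carbon only does not fix the half-life in this assay by itself: trifluoromethyl in place of hydrogen on an aromatic carbon gives a 3.2-fold lower number from compound 1 to compound 3 (0.51 log units; beyond the scatter), so a substituent on that ring also matters in this series. The exchange of furan-2-yl for 4-(trifluoromethyl)phenyl still gives an at least 3.7-fold higher number from compound 2 to compound 3 (0.56 log units; beyond the scatter), which places compound 3 between compound 2 and compound 1 and shows that the gain over furan-2-yl survives the added trifluoromethyl. The value of compound 2 is a limit of the assay and not a number, so the step from it gives only a lower bound: the limit of < 0.075 h in this assay, at which 1 of the 3 values shown sits.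

With trifluoromethyl the only substituent shown on the phenyl ring, it remains open whether a chlorine atom, a methoxy group or an amine at the same place would also give a lower half-life than the unsubstituted phenyl of compound 1. The compounds shown also leave open how a pyridine or thiophene ring on the carbonyl carbon would compare with the furan-2-yl and phenyl groups.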